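Aryl in Place of Benzyl on the Shared Core

The compounds below may be only part of what the source reports. "The series", "measured", "known", "first", "only" and "open" are said of these compounds alone.

Compound 1 `CCCCCCCCCCCCCCCCCCNC(=O)[C@H]1CSC(Cc2ccccc2)N1` is the starting point. In a functional assay on RH7777 cells (Homo sapiens) for antiproliferative activity against RH7777 (Rattus norvegicus), read by sulforhodamine B assay (a lower number here means a stronger inhibitor, a higher number a weaker inhibitor), compound 1 reaches only the limit of the assay, > 20000 nM. Compound 2 `CCCCCCCCCCCCCCCCCCNC(=O)[C@H]1CSC(c2ccc([N+](=O)[O-])cc2)N1` carries a 4-nitrophenyl in place of the benzyl; in this assay compound 2 gives about 20000 nM. The step of a number no higher from compound 1 to compound 2 (the limit leaves the size open) gives no sign of a gain, the starting value sitting at the limit of > 20000 nM in this assay, at which 1 of the 2 values shown sits. Compound 3 `CCCCCCCCCCCCCCCCCCNC(=O)[C@H]1CSC(c2ccc(C#N)cc2)N1` differs from compound 1 by 4-cyanophenyl in place of benzyl on a saturated ring carbon. Among the measured compounds shown here, that single earlier step is the only guide, so for compound 3 a step no larger than the scatter is expected, a number no higher from compound 1 to compound 3 (the limit leaves the size open). Compound 3 is therefore estimated at 20000 nM, within a range from 8000 nM to 50000 nM.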

Compound 3, half-maximal inhibitory concentration: > 20000 nM
Compound 3: a limit, no number; the forecaster's own chance of this, stated with the estimate: 60%; the middle value sits exactly at the limit.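

In this assay compound 3 gives only a limit, > 20000 nM. A second substituted aryl on this saturated ring carbon, now 4-cyanophenyl, therefore brings no measurable value below the limit. Cyano in place of nitro on an aromatic carbon gives a number no lower from compound 2 to compound 3 (the limit leaves the size open), which shows no gain. The step to compound 3 from compound 1 cannot be read, because the values rest on the limit: the limit of > 20000 nM in this assay, at which 2 of the 3 values shown sit.

On these data alone, whether an amine or a carboxylic acid in place of the cyano would give a value clear of the limit stays open.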